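The compounds below may be only part of what the source reports. "The series", "measured", "known", "first", "only" and "open" are said of these compounds alone.

Compound 3 `Nc1nc(-c2ccco2)nc2sc(CN3CC=CC3)cc12` gives 290 nM in an assay on CHO-K1 cells for antagonist activity at adenosine receptor A1 (Homo sapiens), read by a beta-galactosidase reporter, with stated times of 15 min and 6 h (a higher number here means a weaker inhibitor, a lower number a stronger inhibitor), the second-highest of the three numbers seen so far. Compound 2 `Nc1nc(-c2ccco2)nc2sc(CN3CC=CCC3)cc12` gives 150 nM, and the step of a 1.9-fold higher number from compound 2 to compound 3 (0.29 log units; within the scatter) stays within the scatter. Compound 1 `Nc1nc(-c2ccco2)nc2sc(CNC3CC3)cc12` gives 1890 nM, and both a 6.5-fold lower number from compound 1 to compound 3 (0.81 log units; beyond the scatter) and a 13-fold lower number from compound 1 to compound 2 (1.10 log units; beyond the scatter) lie beyond the scatter. Compound 4 `Nc1nc(-c2ncco2)nc2sc(CN3CC=CC3)cc12` carries 1,3-oxazol-2-yl in place of furan-2-yl on an aromatic carbon. All three measured steps change the ring on the saturated chain carbon, so none of them bears on this exchange of the aromatic ring, and neither a direction nor a size can be read from them. Compound 4 is therefore expected to give about 500 nM in this assay, within a range of 150 nM to 1600 nM. The expected step is a 1.7-fold higher number from compound 3 to compound 4 (0.24 log units; within the scatter), a modest change at most.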

Compound 4, inhibition constant: 3890 nM
Estimate against measurement, compound 4: 7.8-fold (0.89 log units) below; measured number outside the range, above it.
By their numbers in this assay, from the lowest: compounds 2 and 3 (each within the scatter of the next); then compound 1; then compound 4.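

For the compounds shown here, on the aromatic carbon between two ring nitrogen atoms, which the earlier compounds left unchanged, this assay proves sensitive to the ring: 1,3-oxazol-2-yl in place of furan-2-yl gives a 13-fold higher number from compound 3 to compound 4 (1.13 log units; beyond the scatter). The two rings hold the same number of heavy atoms, and the entering ring has one nitrogen in place of one carbon, so a single ring-atom exchange here is enough for a large step. Nothing shown gives a reason for this step.

From the compounds shown here alone, whether a thiophen-2-yl or a phenyl group at this position would fall nearer compound 3 or compound 4 remains open. So does whether the same exchange would give a step of like size on compound 2.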